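The compounds below may be only part of what the source reports. "The series", "measured", "known", "first", "only" and "open" are said of these compounds alone.

Of the compounds shown here, three have been measured: compound 1 `CN(C)Cc1ccccc1-c1ccc(N2CCc3c(C(F)(F)F)nn(-c4ccc5onc(N)c5c4)c3C2=O)cc1`, compound 2 `Nc1noc2ccc(-n3nc(C(F)(F)F)c4c3C(=O)N(c3ccc(-c5ccccc5CN5CCCC5)cc3F)CC4)cc12` and compound 3 `CN(C)Cc1ccccc1-c1ccc(N2CCc3c(C(F)(F)F)nn(-c4ccc5onc(N)c5c4)c3C2=O)c(F)c1`. In an in vivo ADME assay on the whole organism for metabolic stability, with Canis familiaris (Canis lupus familiaris) as the target (a lower number here means that the compound disappears faster, a higher number that the compound lasts longer), compound 1 gives 3.8 h, compound 2 gives 4.9 h and compound 3 gives 6.4 h. Compound 1 lies within the usual scatter of both others, as a 1.7-fold higher number from compound 1 to compound 3 (0.23 log units; within the scatter) and a 1.3-fold higher number from compound 2 to compound 3 (0.12 log units; within the scatter) show. Compound 4 `Nc1noc2ccc(-n3nc(C(F)(F)F)c4c3C(=O)N(c3ccc(-c5ccccc5CN5CCC(O)CC5)cc3)CC4)cc12` is compound 1 with one change: 4-hydroxypiperidin-1-yl in place of dimethylamino on a saturated chain carbon bound to an aromatic carbon. Among the measured compounds shown here, the only measured step at that place, a 1.3-fold higher number from compound 2 to compound 3 (0.12 log units; within the scatter), stayed within the scatter, so for compound 4 no step beyond the scatter is expected in this assay and its estimate is 4.5 h, with a range from 2 h to 9 h. That expectation amounts to a 1.2-fold higher number from compound 1 to compound 4 (0.07 log units; within the scatter).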

Compound 4, half-life: 6.4 h
Compound 4: the middle estimate sits 1.4-fold (0.15 log units) below what was measured, within the range that was stated.
By their numbers in this assay, from the lowest: compounds 1, 2, 3 and 4 (each within the scatter of the next).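

With 4-hydroxypiperidin-1-yl in place of dimethylamino, a 1.7-fold higher number from compound 1 to compound 4 (0.23 log units; within the scatter) in this assay shows that this saturated chain carbon can carry a six-membered ring with a hydroxyl group and still stay within the scatter. The earlier step at this place, a 1.3-fold higher number from compound 2 to compound 3 (0.12 log units; within the scatter), covered only pyrrolidin-1-yl and dimethylamino, so the range of groups seen here without a step beyond the scatter is now wider. Nothing available explains this result. The compounds shown leave open whether plain piperidin-1-yl, without the hydroxyl, would behave the same way, and whether a carboxylic acid on that ring would move the half-life beyond the scatter.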